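Working notes on one substituent swap in an antiproliferative series

The source may report more compounds than this note shows. Statements on the series, on what has been measured and on what is new or still open speak of the compounds shown alone.

- compound 1 (`N#Cc1ccc(/C=N/NC(=O)Nc2ccc(Oc3ccnc4[nH]ccc34)c(F)c2)cc1`) gives 9030 nM in a functional assay on PC-3 cells (Homo sapiens) for antiproliferative activity, read by MTT assay, with a stated time of 72 h; a higher number here means a weaker inhibitor, a lower number a stronger inhibitor
- compound 2 (`O=C(N/N=C/c1ccc(F)cc1Cl)Nc1ccc(Oc2ccnc3[nH]ccc23)c(F)c1`) gives 3 nM in this assay

Going by the values given here, compound 2 holds the lowest of the two numbers at 3 nM and compound 1 is its only neighbour. Compound 3 (`COc1ccc(/C=N/NC(=O)Nc2ccc(Oc3ccnc4[nH]ccc34)c(F)c2)cc1`) carries 4-methoxyphenyl in place of 2-chloro-4-fluorophenyl on a carbon with a double bond to nitrogen. Among the compounds with values here, the same place has changed once among the measured compounds, and the result was large: a 3000-fold lower number from compound 1 to compound 2 (3.48 log units; beyond the scatter) with no other measured step bearing on the change. Within the data shown here, that single step gives a poor bound, and 4-methoxyphenyl itself has no measured precedent. Given the spread from compound 2 at 3 nM to compound 1 at 9030 nM in this assay a large step towards a higher number is expected, beyond the scatter but short of the full measured gap. The estimate means a 50-fold higher number from compound 2 to compound 3 (1.70 log units; beyond the scatter) as the expected size. Compound 3 is estimated at 150 nM within an expected range of 6 nM to 4000 nM in these notes.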

Compound 3, half-maximal inhibitory concentration: 6730 nM
Compound 3: middle estimate off by 45-fold (1.65 log units), on the low side; the measured number lies above the stated range.
By their numbers in this assay, from the lowest: compound 2; then compounds 3 and 1 (each within the scatter of the next).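

The step of a 2200-fold higher number from compound 2 to compound 3 (3.35 log units; beyond the scatter) in this assay shows that the large gap at this place, on a carbon with a double bond to nitrogen, is not confined to 4-cyanophenyl, since 4-methoxyphenyl also stands far from 2-chloro-4-fluorophenyl. The step of a 1.3-fold lower number from compound 1 to compound 3 (0.13 log units; within the scatter) stays within the scatter, so methoxy in place of cyano on an aromatic carbon gives no readable change, and among these three compounds only 2-chloro-4-fluorophenyl stands apart, with no compound going against that. Nothing available here offers an explanation for the gap between 2-chloro-4-fluorophenyl and the other two groups.

The compounds shown do not separate the chlorine from the fluorine of 2-chloro-4-fluorophenyl, so it stays open whether 2-chlorophenyl or 4-fluorophenyl alone would reach a number close to that of compound 2. On these data alone, it is also open how an amine or a carboxylic acid on the phenyl ring would read at this place, and whether any group other than 2-chloro-4-fluorophenyl gives a low number here.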